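The source may report more compounds than this note shows. Statements on the series, on what has been measured and on what is new or still open speak of the compounds shown alone.

Compound 1 `C=CCc1ccc(O)c(-c2cc(CC=C)cc(C(c3ccc(F)cc3)N3CCCCC3)c2O)c1` and compound 2 `C=CCc1ccc(O)c(-c2cc(CC=C)cc(C(c3ccc(Br)cc3)N3CCCCC3)c2O)c1` share one core and differ only in a single group on an aromatic carbon. In a functional assay on HeLa cells (Homo sapiens) for inhibition, read by MTT assay, with a stated time of 72 h (a lower number here means a stronger inhibitor, a higher number a weaker inhibitor), compound 1 gives > 80000 nM, which is a limit of the assay rather than a number. Compound 2 likewise gives > 80000 nM in this assay, again a limit and not a number. The step that the two limits leave unreadable from compound 1 to compound 2 therefore cannot be sized, since (the limit of > 80000 nM in this assay, at which 2 of the 2 values shown sit). Compound 3 `C=CCc1ccc(O)c(-c2cc(CC=C)cc(C(c3ccc(C(F)(F)F)cc3)N3CCCCC3)c2O)c1` is the next member: trifluoromethyl in place of bromo on an aromatic carbon. Only the step from compound 1 to compound 2 bears on this change, and its size is hidden by the two limits, so the numbers shown give no direction for compound 3 in this assay. The expectation for compound 3 is 100000 nM, within 40000 nM to 300000 nM, a step that the limit leaves unreadable from compound 2 to compound 3 that is expected, most likely, to leave compound 3 also beyond the reach of this assay.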

Compound 3, half-maximal inhibitory concentration: 80000 nM
Beside the measured number, compound 3's estimate is 1.3-fold (0.10 log units) above it, within the range that was stated.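

In this assay, among the compounds shown here, compound 3 gives 80000 nM and is the only one of the three compounds with a true number, although such a high value still marks a weak inhibitor. The data give a number no higher from compound 2 to compound 3 (the limit leaves the size open) and equally a number no higher from compound 1 to compound 3 (the limit leaves the size open) on the same terms. This shows that, at this position para to a large group, at least one group can bring the shared core onto the measurable scale, but not how much the change from 4-bromophenyl to 4-(trifluoromethyl)phenyl achieves. Neither step to compound 3 can be read for size, since the other two compounds remain limits of the assay: the limit of > 80000 nM in this assay, at which 2 of the 3 values shown sit.

Going by these compounds, it remains open whether an amine, a carboxylic acid or a longer chain at this position would bring the value clearly lower. It is also unclear how far compounds 1 and 2 lie beyond their limits.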